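A few compounds are considered here, and "the series" means these few. Any claim that something is new, unique, unknown or untested is made for them only; others in the source may bear on it.

Among the measured compounds shown here, compound 3, whose structure is `O=C(NCc1ccc(S(=O)(=O)c2ccccc2)cc1)c1c[nH]c2ccncc12`, is the weakest of the three compounds measured so far in a functional assay on A2780 cells (Homo sapiens) for inhibition, read by sulforhodamine B assay, with a stated time of 72 h; a higher number here means a weaker inhibitor, a lower number a stronger inhibitor. In that assay compound 3 gives 2100 nM. Its nearest neighbour on the numbers is compound 2, with structure `O=C(NCc1ccc(S(=O)(=O)c2cccc(F)c2)cc1)c1cc2cnccc2[nH]1`, which gives 11 nM in this assay, and the strongest of the set is compound 1, with structure `O=C(NCc1ccc(S(=O)(=O)c2cccc(C(F)(F)F)c2)cc1)c1cc2cnccc2[nH]1`, which gives 3 nM in this assay. For the measured compounds named here, the one step measured so far, a 3.7-fold higher number from compound 1 to compound 2 (0.56 log units; beyond the scatter), concerns the substituent on the sulfone-bearing ring, and it was modest.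

Compound 4, with structure `O=C(NCc1ccc(S(=O)(=O)c2ccccc2)cc1)c1cc2cnccc2[nH]1`, is compound 3 with a changed core: a group of 9 heavy atoms (7 carbon, 2 nitrogen; one five-membered aromatic ring with 1 hetero atom, one six-membered aromatic ring with 1 hetero atom) in place of a group of 9 heavy atoms (7 carbon, 2 nitrogen; one five-membered aromatic ring with 1 hetero atom, one six-membered aromatic ring with 1 hetero atom), on a carbonyl carbon. Going by the values given here, no measured step bears directly on this change. Among the compounds with values here, what does bear on it is that compound 4 shares the core of compounds 1 and 2 and differs from compound 2 only in lacking the fluoro, while compound 3 is the only measured compound with the other arrangement of the core. Compound 4 is therefore expected to land much nearer to compound 2, because compound 2 gives 11 nM in this assay, with some further weakening beyond a 3.7-fold higher number from compound 1 to compound 2 (0.56 log units; beyond the scatter) allowed for. The expected step is a 70-fold lower number from compound 3 to compound 4 (1.85 log units; beyond the scatter), and the estimate for compound 4 in this assay is 30 nM, within a range from 8 nM to 120 nM.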

Compound 4, half-maximal inhibitory concentration: 18 nM
Compound 4: middle estimate off by 1.7-fold (0.22 log units), on the high side; the range from low to high includes it.
By their numbers in this assay, from the lowest: compound 1; then compounds 2 and 4 (each within the scatter of the next); then compound 3.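

In this assay, among the compounds shown here, the change of core gives a 120-fold lower number from compound 3 to compound 4 (2.07 log units; beyond the scatter) with the same atoms joined differently on the carbonyl carbon, which separates the effect of the core from that of the substituent on the sulfone-bearing ring, something the earlier compounds could not do since compound 3 differed from each of them in more than one place. Removing the substituent gives a 1.6-fold higher number from compound 2 to compound 4 (0.21 log units; within the scatter) and so leaves hydrogen and fluoro unresolved at this position, whereas a 6.0-fold higher number from compound 1 to compound 4 (0.78 log units; beyond the scatter) shows that trifluoromethyl gives a real gain over hydrogen, though one far smaller than the step from the core change. Nothing given here accounts for the size of the core step or for the gain with trifluoromethyl.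

As far as these compounds go, the core comparison rests on a single pair with an unsubstituted ring, so it remains open whether trifluoromethyl or fluoro on the ring of compound 3 would bring a similar change. From the compounds shown here alone, it is also open how a chloro, a methoxy or an amine on the sulfone-bearing ring would compare with trifluoromethyl on the shared core.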